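Compound 3: pyridin-2-yl in place of furan-2-yl

This account rests on a few compounds, and the source may have more. Where it says the series, first, only, none or still open, it means among the compounds named here.

Two members of the series have numbers in a functional assay on DU-145 cells (Homo sapiens) for cytotoxicity, read by CCK-8 assay; a higher number here means a weaker inhibitor, a lower number a stronger inhibitor. Compound 1 `Oc1cccc(-c2cc(-c3ccco3)cc(-c3cccc(O)c3)n2)c1` gives 2150 nM. Compound 2 `Oc1ccc(-c2cc(-c3ccco3)cc(-c3cccc(O)c3)n2)cc1` gives 2070 nM. Compound 1 carries the highest of the two numbers, but the step of a 1.0-fold lower number from compound 1 to compound 2 (0.02 log units; within the scatter) lies within the scatter, so the two compounds cannot be told apart on these data. Compound 3 `Oc1cccc(-c2cc(-c3ccccn3)cc(-c3cccc(O)c3)n2)c1` has not yet been measured. It differs from compound 1 in one place: pyridin-2-yl in place of furan-2-yl on an aromatic carbon. Among the compounds with values here, no measured step bears on this change; the only step available exchanges 4-hydroxyphenyl for 3-hydroxyphenyl and leaves the furan-2-yl untouched. The expectation for compound 3 therefore rests on the level of compound 1 at 2150 nM, and no step beyond the scatter is assumed in either direction. The step from compound 1 to compound 3 is estimated at a 1.1-fold lower number from compound 1 to compound 3 (0.03 log units; within the scatter). Compound 3 is expected to give 2000 nM, within 700 nM to 6000 nM.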

Compound 3, half-maximal inhibitory concentration: 3610 nM
The estimate for compound 3 lay 1.8-fold (0.26 log units) below the measured number; the measured number falls inside the stated range.
By their numbers in this assay, from the lowest: compounds 2, 1 and 3 (each within the scatter of the next).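

At the carbon opposite the ring nitrogen, pyridin-2-yl in place of furan-2-yl gives a 1.7-fold higher number from compound 1 to compound 3 (0.23 log units; within the scatter) in this assay, so the two groups cannot be told apart on these data. The step between compound 1 and compound 2 concerned only a hydroxyphenyl group, whereas this pair shows that a six-membered aromatic ring with 1 hetero atom can replace a five-membered one at this position without a step beyond the scatter. Nothing measured on hand bears on the size of this step.

As far as these compounds go, whether an amine, a carboxylic acid or a longer alkyl chain at this position would give a step beyond the scatter remains open. Also open, from the compounds shown here alone, is how pyridin-2-yl reads alongside the 4-hydroxyphenyl group of compound 2.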